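This account rests on a few compounds, and the source may have more. Where it says the series, first, only, none or still open, it means among the compounds named here.

Of the compounds shown here, two of the same core have been measured in a functional assay on HEK293 cells with prostaglandin E2 receptor EP4 subtype (Rattus norvegicus) as the target, read by cAMP accumulation; a lower number here means that less compound is needed, a higher number that more compound is needed for the effect. Compound 1, `O=C(O)c1ccc(CCCN2C(=O)CC[C@@H]2CCC(O)Cc2ccc3ccccc3c2)s1`, carries a naphthalen-2-yl group on the chain that bears the hydroxyl, and in this assay compound 1 gives 500 nM. Among the measured compounds shown here, compound 2, `O=C(O)c1ccc(CCCN2C(=O)CC[C@@H]2CC[C@@H](O)Cc2cccc(Cl)c2)s1`, differs from it in more than one place, so no single step between the two can be read; in this assay compound 2 gives 0.6 nM. Compound 1 therefore stands at the higher of the two numbers, and the gap to compound 2 lies well beyond the scatter of repeated runs.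

Compound 3, `CCc1ccc(CC(O)CC[C@H]2CCC(=O)N2CCCc2ccc(C(=O)O)s2)cc1`, has not yet been measured. It is derived from compound 1 by a single change: 4-ethylphenyl in place of naphthalen-2-yl on a saturated chain carbon, two bonds along the chain from an oxygen on a saturated carbon. For the measured compounds named here, no measured pair shows exactly this change, but the only other measured compound, compound 2, carries a single six-membered aromatic ring at the same place and gives a far lower number than compound 1. A sizeable drop is therefore expected, estimated as a 25-fold lower number from compound 1 to compound 3 (1.40 log units; beyond the scatter). For compound 3 in this assay the expected value is 20 nM, with a likely range from 3 nM to 150 nM.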

Compound 3, half-maximal effective concentration: 275 nM
Compound 3: the middle estimate sits 14-fold (1.14 log units) below what was measured, and the stated range ends below it.
By their numbers in this assay, from the lowest: compound 2; then compounds 3 and 1 (each within the scatter of the next).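

In this assay, placing 4-ethylphenyl where naphthalen-2-yl stood gives a 1.8-fold lower number from compound 1 to compound 3 (0.26 log units; within the scatter), so this change makes no clear difference. Going from two six-membered aromatic rings to one at this place, and from 10 heavy atoms to 8, is therefore not enough on its own to reach the number of compound 2, 0.6 nM. Nothing measured here explains why the two groups give values within the scatter of each other.

Compound 3 and compound 2 differ in more than one place, including the group on the ring and the drawn configuration at the hydroxyl-bearing carbon, so no step between them can be read, and the shown compounds cannot tell which difference goes with the much lower number of compound 2. A plain phenyl group at this place, a chlorine on the ring of compound 3 in place of its ethyl group, and a version of compound 3 with the hydroxyl-bearing carbon drawn as in compound 2 would each separate one of these differences in this assay.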